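A few compounds are considered here, and "the series" means these few. Any claim that something is new, unique, unknown or untested is made for them only; others in the source may bear on it.

Measured so far:
Compound 1 `CC#CCn1c(N2CCC[C@@H](N)C2)cc(=O)n(Cc2cccc(C(=O)OC)c2Br)c1=O`. In an assay on isolated protein for inhibition of Dipeptidyl peptidase 9 (Homo sapiens), read by fluorescence, with stated times of 15 min and 20 min (a lower number here means a stronger inhibitor, a higher number a weaker inhibitor), compound 1 gives > 100 nM, which is a limit of the assay.
Compound 2 `CC#CCn1c(N2CCC[C@@H](N)C2)cc(=O)n(Cc2ccc(Br)c(C(=O)OC)c2)c1=O`. In this assay compound 2 gives > 100 nM, again a limit.
Compound 3 `CC#CCn1c(N2CCC[C@@H](N)C2)cc(=O)n(Cc2ccc(F)c(C(=O)OC)c2)c1=O`. In this assay compound 3 gives > 100 nM, also a limit.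

None of the three compounds therefore has a number in this assay; all three sit at the limit of > 100 nM in this assay, at which 3 of the 3 values shown sit. Among the compounds with values here, the one change made between measured compounds, from compound 2 to compound 3, is fluoro in place of bromo on an aromatic carbon, and the result is a step that the two limits leave unreadable from compound 2 to compound 3. Compound 1 and compound 2 share the same atoms joined differently; the difference between the two cores is not broken down here.

Compound 4 `CC#CCn1c(N2CCC[C@@H](N)C2)cc(=O)n(Cc2cccc(C(=O)OC)c2F)c1=O` has not yet been measured in this assay. It differs from compound 1 by fluoro in place of bromo on an aromatic carbon. This is the same kind of change as that from compound 2 to compound 3, but not the same: in compound 2 the exchanged atom sits ortho to a methoxycarbonyl group and para to a large group, whereas in compound 1 it sits ortho to a large group and ortho to a methoxycarbonyl group.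

Because compound 1 shows only > 100 nM, and because the related exchange gave a step that the two limits leave unreadable from compound 2 to compound 3, the step from compound 1 to compound 4 is expected to be a step that the limit leaves unreadable from compound 1 to compound 4, a size that cannot be read from the two limits. Compound 4 is accordingly estimated at 300 nM in this assay, with a range of 100 nM to 3000 nM, and most likely only a limit will be reported.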

Compound 4, half-maximal inhibitory concentration: > 100 nM
Compound 4: no number, only a limit; the forecaster's own chance of this, stated with the estimate: 85%; the middle value is on the limit's open side.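

In this assay compound 4 gives > 100 nM, which is a limit of the assay. Compound 1 also stands only at a limit, so no step can be read for fluoro in place of bromo between compound 1 and compound 4, and the values shown all stand together: the limit of > 100 nM in this assay, at which 4 of the 4 values shown sit.

The compounds shown leave open how strongly any of them inhibits the enzyme, and whether either exchange of bromo for fluoro changes that.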